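The compounds below may be only part of what the source reports. "The series", "measured", "known", "first", "only" and "open" are said of these compounds alone.

Measured so far:
- compound 1, `N#C[Se]c1ccc(NC(=O)Oc2ccc(F)cc2)cc1`, gives 45600 nM
- compound 2, `CCCCOC(=O)Nc1ccc([Se][Se]c2ccc(NC(=O)OCCCC)cc2)cc1`, gives 49600 nM
- compound 3, `O=C(Nc1ccc([Se][Se]c2ccc(NC(=O)OCc3ccccc3)cc2)cc1)OCc1ccccc1`, gives 17300 nM

All three numbers come from an ADME assay on BEAS-2B cells (Homo sapiens) for cytotoxicity, read by MTT assay, with a stated time of 72 h; on this read-out lower numbers stand for stronger inhibition of growth and higher numbers for weaker inhibition of growth. Compound 1 stands second highest of the three. Compound 2 sits nearest, and the gap between compound 1 and compound 2 lies within the scatter, so no order between them can be read. Going by the values given here, compound 3 sits furthest from compound 1, with a number that is lower and beyond the scatter; no single-point step connects compound 3 to compound 1, so only the two values themselves are noted.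

The next compound, compound 4, `Cc1ccc(OC(=O)Nc2ccc([Se]C#N)cc2)cc1`, is related to compound 1 by one change: methyl in place of fluoro on an aromatic carbon. Among the compounds with values here, no pair of measured compounds shows the effect of such a change in this assay, so nothing in the data points to either direction. The expectation for the step from compound 1 to compound 4 in this assay is a 1.1-fold lower number from compound 1 to compound 4 (0.04 log units; within the scatter), that is, none beyond the scatter. On that basis compound 4 is expected to give about 42000 nM in this assay, with a range from 20000 nM to 90000 nM.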

Compound 4, concentration for total growth inhibition: 15300 nM
The estimate for compound 4 lay 2.7-fold (0.44 log units) above the measured number; measured number below the stated range.
By their numbers in this assay, from the lowest: compounds 4 and 3 (each within the scatter of the next); then compounds 1 and 2 (each within the scatter of the next).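

Methyl in place of fluoro, on an aromatic carbon para to a large group, gives in this assay a 3.0-fold lower number from compound 1 to compound 4 (0.47 log units; beyond the scatter). Going by these compounds alone, this is the first step that isolates a single place, and it shows that exchanging one heavy atom for another at this position, with no ring, hydrogen-bond donor, hydrogen-bond acceptor or net charge entering or leaving, can move the number beyond the scatter. No evidence at hand bears on why the step runs in this direction.

Going by these compounds, with a single step at this position, it remains open whether a longer chain such as ethyl, or a methoxy group, an amine or a carboxylic acid, would follow methyl or fluoro. On these data alone, it also remains open whether the same exchange would give a similar step on another scaffold.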